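The compounds below may be only part of what the source reports. "The series", "measured", "known", "first", "only" and "open" are said of these compounds alone.

Measured compounds in an assay on HEK293 cells for inhibition of nuclear factor NF-kappa-B complex (Homo sapiens), read by a luciferase reporter, with stated times of 1 h and 3 h; a lower number here means a stronger inhibitor, a higher number a weaker inhibitor:
- compound 1 `Cc1ccc(CNC(=O)[C@H](CCc2ccccc2)NC(=O)[C@H](CCc2ccccc2)NC(=O)[C@H](CCc2ccccc2)NC(=O)c2cnc(C)cn2)cc1`: 45 nM
- compound 2 `CC(C)(C)CNC(=O)C[C@H](NC(=O)C(C)(C)C)C(=O)N[C@@H](CCc1ccccc1)C(=O)NCc1ccccc1`: 62 nM
- compound 3 `CC(C)(C)CNC(=O)C[C@H](NC(=O)c1ccc(OCc2ccccc2)cc1)C(=O)N[C@@H](CCc1ccccc1)C(=O)NCc1ccccc1`: 22 nM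

Among these three, compound 2 gives the highest number, but its gap to compound 1 lies within the usual scatter, so the two cannot be told apart. Compound 3 gives the lowest number, and its gap to compound 2 is beyond the scatter, so of that pair compound 3 is the stronger inhibitor.

Compound 4 `Cc1cc(C(=O)N[C@@H](CC(=O)NCC(C)(C)C)C(=O)N[C@@H](CCc2ccccc2)C(=O)NCc2ccccc2)no1` has not yet been measured. It differs from compound 2 in one place: 5-methyl-1,2-oxazol-3-yl in place of tert-butyl on a carbonyl carbon. For the measured compounds named here, no pair of measured compounds shares exactly this change, so the expectation rests only on the three values above. Compound 3 also ends in an aromatic ring rather than a tert-butyl, and gives 22 nM, which points to a number somewhat lower than that of compound 2 for compound 4.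

The step of a 1.6-fold lower number from compound 2 to compound 4 (0.19 log units; within the scatter) is therefore expected to be small, downward, and probably not clearly beyond the scatter. Compound 4 is expected to give about 40 nM, with a range from 15 nM to 110 nM.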

Compound 4, half-maximal inhibitory concentration: 9 nM
Beside the measured number, compound 4's estimate is 4.4-fold (0.65 log units) above it; measured number outside the range, below it.
By their numbers in this assay, from the lowest: compound 4; then compound 3; then compounds 1 and 2 (each within the scatter of the next).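

In this assay, putting 5-methyl-1,2-oxazol-3-yl in place of tert-butyl on this carbonyl carbon gives a 6.9-fold lower number from compound 2 to compound 4 (0.84 log units; beyond the scatter) and so lies beyond the scatter. For the compounds shown here, the earlier compounds included no pair differing in one place, so this is the first direct sign that the group on this carbonyl carbon can shift the number on its own. The change brings in a five-membered aromatic ring with two hydrogen-bond acceptors, but no measurement shown explains the lower number.

As far as these compounds go, how the unsubstituted 1,2-oxazol-3-yl or a plain phenyl would compare on the same carbonyl carbon remains open, so it is unclear whether the methyl, the hetero atoms or the ring itself matters most. Also open, from the compounds shown here alone, is whether this change would give a similar step on another core, such as that of compound 1.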